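This account rests on a few compounds, and the source may have more. Where it says the series, first, only, none or still open, it means among the compounds named here.

The measured compounds are:
compound 1 `O=C(C1CC1)N1CC2CC1CN2`; in an assay on SH-EP1 cells for displacement of a labelled ligand from Neuronal acetylcholine receptor; alpha4/beta2 (Homo sapiens), read by scintillation counting (on this read-out lower numbers stand for stronger inhibition and higher numbers for weaker inhibition), compound 1 gives 2800 nM.
compound 2 `CC(=O)N1CC2CC(C1)N2`; in this assay compound 2 gives 150 nM.
compound 3 `CC(C)C(=O)N1CC2CC(C1)N2`; in this assay compound 3 gives 130 nM.

Among these three numbers, compound 2 stands second highest. Within the data shown here, its nearest neighbour is compound 3, which lies within the scatter of it, and its furthest is compound 1, whose number is beyond the scatter higher; compound 1 is built on a different core, so no single-place step links it to compound 2, and its value is taken only as it stands.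

Compound 4 `O=C(C1CCC1)N1CC2CC(C1)N2` is not yet measured. It differs from compound 2 in one place: cyclobutyl in place of methyl on a carbonyl carbon. Among the measured compounds shown here, only one measured step bears on this change, the enlargement of the group on the same carbonyl carbon from compound 2 to compound 3, which gave a 1.2-fold lower number from compound 2 to compound 3 (0.06 log units; within the scatter). Because that step, a 1.2-fold lower number from compound 2 to compound 3 (0.06 log units; within the scatter), stayed within the scatter, a further growth of the group on the carbonyl carbon to cyclobutyl is expected to move the number little, if at all, and the step from compound 2 to compound 4 is estimated as no change at the digits printed from compound 2 to compound 4 (within the scatter). Compound 4 is therefore expected to give about 150 nM in this assay, within a range from 60 nM to 400 nM.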

Compound 4, inhibition constant: 16 nM
Compound 4: middle estimate off by 9.4-fold (0.97 log units), on the high side; the whole stated range lies above it.
By their numbers in this assay, from the lowest: compound 4; then compounds 3 and 2 (each within the scatter of the next); then compound 1.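

The carbonyl carbon attached to the amide-type nitrogen in a ring had looked insensitive when isopropyl replaced methyl, but in this assay it proves responsive to the group placed there: cyclobutyl in place of methyl gives a 9.4-fold lower number from compound 2 to compound 4 (0.97 log units; beyond the scatter), and cyclobutyl in place of isopropyl gives an 8.1-fold lower number from compound 3 to compound 4 (0.91 log units; beyond the scatter). The number at this place therefore does not follow a simple departure from methyl, since among these three compounds only cyclobutyl, the one group here that carries a four-membered ring of carbon, moves it beyond the scatter. Nothing available here accounts for the difference between cyclobutyl and the other two groups.

The three compounds on the shared core cannot separate the presence of a ring from the number of carbons in the group, so a longer chain such as n-butyl would be needed alongside cyclobutyl to draw that distinction. From the compounds shown here alone, it also remains open whether the lower number extends to other rings on the same carbonyl carbon, such as cyclopentyl or phenyl, or belongs to cyclobutyl alone.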